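The compounds below may be only part of what the source reports. "The series", "measured", "known", "first", "only" and "open" are said of these compounds alone.

Measured compounds in an ADME assay on HepG2 cells (Homo sapiens) for cytotoxicity, read by luminescence, CellTiter-Glo and ATP content, with a stated time of 72 h; a lower number here means that less compound is needed, a higher number that more compound is needed for the effect: compound 1 `Fc1ccc(Cc2ccc3c(NCCCNCc4ccco4)ccnc3c2)cc1` gives 5600 nM; compound 2 `COc1cccc(CNCCCNc2ccnc3cc(Cc4ccc(F)cc4)ccc23)c1O` gives 4780 nM; compound 3 `COc1ccc(F)cc1CNCCCNc1ccnc2cc(Cc3ccc(F)cc3)ccc12` gives 3530 nM.

Compound 2 has the second highest of these three numbers, and the three lie within the scatter of one another: a 1.2-fold lower number from compound 1 to compound 2 (0.07 log units; within the scatter), a 1.4-fold lower number from compound 2 to compound 3 (0.13 log units; within the scatter), and a 1.6-fold lower number from compound 1 to compound 3 (0.20 log units; within the scatter). Compound 4 `COc1cccc(CNCCCNc2ccnc3cc(Oc4ccc(C(C)(C)C)cc4)ccc23)c1O` differs from compound 2 at another site: 4-(tert-butyl)phenoxy in place of 4-fluorobenzyl on an aromatic carbon. Among the compounds with values here, every measured step changed only the group on the saturated chain carbon bound to an amine nitrogen, so no measured step touches the aromatic carbon altered here. Within the data shown here, with no step bearing on it, compound 4 is expected to stay close to compound 2, a 1.1-fold lower number from compound 2 to compound 4 (0.06 log units; within the scatter), with a wide range. Compound 4 is estimated at 4200 nM, between 1400 nM and 13000 nM.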

Compound 4, half-maximal effective concentration: 1500 nM
For compound 4 the middle estimate is 2.8-fold (0.45 log units) above the measured one; low and high end bracket the measured number.
By their numbers in this assay, from the lowest: compound 4; then compounds 3, 2 and 1 (each within the scatter of the next).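

In this assay the aromatic carbon emerges as a site where the number can move: a 3.2-fold lower number from compound 2 to compound 4 (0.50 log units; beyond the scatter) comes with 4-(tert-butyl)phenoxy in place of 4-fluorobenzyl. This modest step is the only one beyond the scatter, as all changes on the saturated chain carbon stayed within it. Nothing available accounts for this step.

The compounds shown leave open whether the ether oxygen or the tert-butyl group goes with the lower number. A 4-fluorophenoxy or 4-(tert-butyl)benzyl group on this carbon would separate the two.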